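What happens when compound 3 loses its hydroxy?

The compounds below may be only part of what the source reports. "The series", "measured", "known", "first", "only" and "open" are said of these compounds alone.

Compound 1 `CCCCCC[C@@H](O)C/C=C\CCCCCCCC(=O)N[C@@H](C)c1ccccc1` gives 5.1 ug/mL
Compound 2 `CCCCCCCC/C=C\CCCCCCCC(=O)N1CCCC1` gives 5.2 ug/mL
Compound 3 `CCCCCC[C@@H](O)C/C=C\CCCCCCCC(=O)N1CCOCC1` gives 41.8 ug/mL

These values come from a functional assay on MCF7 cells (Homo sapiens) for antiproliferative activity, read by sulforhodamine B assay, with a stated time of 48 h (on this read-out higher numbers stand for weaker inhibition of growth and lower numbers for stronger inhibition of growth), and compound 3 holds the highest number of the three (41.8 ug/mL), so it inhibits growth the least. For the measured compounds named here, the next molecule to be measured is compound 4 `CCCCCCCC/C=C\CCCCCCCC(=O)N1CCOCC1` and only one place changes on the way from compound 3 (hydrogen in place of hydroxy on a saturated chain carbon bound to two saturated chain carbons): hydrogen in place of hydroxy on a saturated chain carbon bound to two saturated chain carbons.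

Going by the values given here, no measured pair shows this change alone. Among the compounds with values here, the one measured step (an 8.2-fold higher number from compound 1 to compound 3 (0.91 log units; beyond the scatter)) swaps morpholin-4-yl in place of (1-phenylethyl)amino on a carbonyl carbon, and both of its compounds keep the hydroxy. It shows that the group on the carbonyl can matter, but says nothing direct about the hydroxy. Compound 2 has no hydroxy and gives 5.2 ug/mL in this assay but it also carries a different group on the carbonyl, so its gap from compound 3 cannot be assigned to the hydroxy alone. Only part of that gap is therefore expected to appear. The estimated step is a 2.8-fold lower number from compound 3 to compound 4 (0.45 log units; beyond the scatter) towards stronger inhibition of growth. For compound 4 the expected value is 15 ug/mL (estimated range 5 ug/mL to 45 ug/mL).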

Compound 4, concentration for 50% growth inhibition: 4.9 ug/mL
Compound 4: middle estimate off by 3.1-fold (0.49 log units), on the high side; measured number below the stated range.
By their numbers in this assay, from the lowest: compounds 4, 1 and 2 (each within the scatter of the next); then compound 3.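

In this assay, for the compounds shown here, the hydroxy on this saturated chain carbon proves to be the single change that separates compound 3 from its hydroxy-free partner, and removing it gives much stronger inhibition of growth (an 8.5-fold lower number from compound 3 to compound 4 (0.93 log units; beyond the scatter)). Once the hydroxy is gone, morpholin-4-yl and pyrrolidin-1-yl on the carbonyl carbon cannot be told apart (a 1.1-fold lower number from compound 2 to compound 4 (0.03 log units; within the scatter)), so the weak result for compound 3 cannot be read as a general penalty for morpholin-4-yl on this hydroxy-free chain. Nothing here gives a measured reason why the hydroxy has this effect on growth inhibition.

The compounds shown leave open whether the hydroxy costs as much alongside other carbonyl groups, since compound 1 keeps both its hydroxy and its (1-phenylethyl)amino group and has no hydroxy-free partner here. They also leave open how the chain would respond if a methoxy group or an amine stood in place of the hydroxy on the same carbon, and whether either would track compound 3 or compound 4.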